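Swapping a Ring for a Chain on a Shared Core

This account rests on a few compounds, and the source may have more. Where it says the series, first, only, none or still open, it means among the compounds named here.

Three compounds built on one shared core were run through an ADME assay on microsomes from liver (Homo sapiens) for metabolic stability, read by LC-MS, using NADPH, with a stated time of 1 h, tested at 10 uM; on this read-out lower numbers stand for slow clearance and higher numbers for fast clearance. Compound 1, `Cn1nc(CN2CCN(c3ccccc3)CC2)nc1-c1ccc(C(C)(C)C)cc1`, gave 18.6 mL.min-1.g-1. Compound 2, `Cn1nc(CN2CCCC2)nc1-c1ccc(Cl)c(Cl)c1`, gave 8.2 mL.min-1.g-1. Compound 3, `Cn1nc(CN2CCCC2)nc1-c1ccc(C2(C(F)(F)F)CC2)cc1`, gave 4 mL.min-1.g-1, the lowest of the three numbers; its nearest neighbour is compound 2, separated by a gap beyond the usual scatter, and the furthest is compound 1.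

Compound 4, `Cn1nc(CN2CCCC2)nc1-c1ccc(C(C)(C)C)cc1`, has not yet been measured. It differs from compound 3 in a single place: tert-butyl in place of 1-(trifluoromethyl)cyclopropyl on an aromatic carbon. Going by the values given here, no two measured compounds differ in only one place, so no measured step speaks directly to this change. Compound 1 also carries a tert-butyl group and gave 18.6 mL.min-1.g-1 in this assay, but it carries a different amine on the other side of the core, so its number cannot be read as the effect of the tert-butyl group alone.

An increase is nonetheless expected for compound 4 in this assay, because compound 1 with its tert-butyl group stands at 18.6 mL.min-1.g-1 while compound 3 stands at 4 mL.min-1.g-1. The step from compound 3 to compound 4 is expected to be a 3.0-fold higher number from compound 3 to compound 4 (0.48 log units; beyond the scatter), beyond the scatter. Compound 4 is estimated at 12 mL.min-1.g-1, with a range from 6 mL.min-1.g-1 to 25 mL.min-1.g-1.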

Compound 4, intrinsic clearance in microsomes: 5.8 mL.min-1.g-1
For compound 4 the middle estimate is 2.1-fold (0.32 log units) above the measured one; the whole stated range lies above it.
By their numbers in this assay, from the lowest: compounds 3, 4 and 2 (each within the scatter of the next, the first and the last beyond it); then compound 1.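

In this assay, going by these compounds alone, replacing 1-(trifluoromethyl)cyclopropyl with tert-butyl on this aromatic carbon gives a 1.5-fold higher number from compound 3 to compound 4 (0.16 log units; within the scatter), so this exchange, which removes the three-membered ring and the three fluorine atoms, produces no step that stands clear of the scatter. With the amine of compound 3 kept in place, the tert-butyl compound 4 gives 5.8 mL.min-1.g-1 in this read-out, whereas compound 1, which carries the same tert-butyl group and differs only in its amine, gives 18.6 mL.min-1.g-1, so the tert-butyl group alone does not bring the high number seen for compound 1. Nothing in the data shown explains why compound 3 and compound 4 fall within the scatter of each other.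

As far as these compounds go, what remains open is whether the two groups would also stay within the scatter of each other when paired with the amine of compound 1 on the other side of the shared core. From the compounds shown here alone, it also remains open how a nitrile, a methoxy group or a lone trifluoromethyl group on the same aromatic carbon would read in this assay alongside these two groups.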